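The source may hold more compounds than are shown below. What is called first, only, known or untested is meant among the compounds shown, and "the series" means these compounds.

Working notes. Compound 1 `COc1ccc(Br)cc1C(=O)Nc1ccc(Sc2nc3ccccc3s2)cc1` carries a bromo group on its methoxy-substituted ring. In an assay on isolated protein for inhibition of thiosulfate sulfurtransferase (Homo sapiens), with a stated time of 60 min, in the absence of a further agent (on this read-out higher numbers stand for weaker inhibition and lower numbers for stronger inhibition), compound 1 gives only a limit of the assay, > 100000 nM. Compound 2 `COc1ccc(Br)cc1C(=O)Nc1ccccc1` in this assay also gives only a limit, > 100000 nM. Both values sit together at the limit of > 100000 nM in this assay, at which 2 of the 2 values shown sit, so nothing places compound 1 anywhere on a numerical scale. Compound 3 `COc1ccccc1C(=O)Nc1ccc(Sc2nc3ccccc3s2)cc1` differs from compound 1 by hydrogen in place of bromo on an aromatic carbon. For the measured compounds named here, no measured step covers this change. The expected step is a step that the limit leaves unreadable from compound 1 to compound 3, none beyond the scatter. Compound 3 is therefore estimated at 200000 nM, with a range of 50000 nM to 1000000 nM, most likely reported again only as a limit.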

Compound 3, half-maximal inhibitory concentration: > 100000 nM
Compound 3: no number, only a limit; the forecaster's own chance of this, stated with the estimate: 90%; the middle value does not contradict the limit.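

No step can be read from compound 1 to compound 3, because both give only a limit in this assay: the limit of > 100000 nM in this assay, at which 3 of the 3 values shown sit. As far as these compounds go, whether 5-bromo-2-methoxyphenyl and 2-methoxyphenyl differ at all in inhibition remains open, as does any numerical potency for these compounds.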